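Swapping an aryl group on a triazole in a pancreatic-cancer cell assay

A few compounds are considered here, and "the series" means these few. Any claim that something is new, unique, unknown or untested is made for them only; others in the source may bear on it.

Three compounds share a related phenol-bearing core and were tested in a functional assay on MIA PaCa-2 cells (Homo sapiens) for inhibition, read by MTT assay, with a stated time of 72 h, tested at 30 uM; a higher number here means more inhibition of growth at the concentration tested, a lower number less inhibition of growth. Compound 1, with structure `C=CCc1ccc(OCc2cn(-c3ccccc3Cl)nn2)c(O)c1`, gives 46.6%. Compound 2, with structure `C#CCOc1ccc(CC=C)cc1O`, gives 27.4% in this assay. Compound 3, with structure `C=CCc1cc(O)c(O)c(CN2CCC(C)CC2)c1`, gives 91.5% in this assay. Among these three numbers, compound 1 stands second highest: compound 2 lies below it by a gap beyond the usual scatter, and compound 3 lies above it by a considerably larger gap, also beyond the scatter.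

Compound 4, with structure `C=CCc1ccc(OCc2cn(-c3ccc(C#N)cc3)nn2)c(O)c1`, has not yet been measured. It differs from compound 1 in one place: 4-cyanophenyl in place of 2-chlorophenyl on an aromatic nitrogen. The rest of the molecule, including the triazole and the phenol-bearing core, is unchanged.

Among the measured compounds shown here, no pair of measured compounds differing in one place is available, so there is no measured step to lean on. The change is a swap of one aromatic group for another of similar size on the same aromatic nitrogen. The expected step of a number 1.6 percentage points lower from compound 1 to compound 4 (within the scatter) is small, likely not beyond the scatter, in no firm direction. Compound 4 is therefore expected to give 45% in this assay, within a range from 25% to 65%.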

Compound 4, percent growth inhibition at one concentration: 39.3%
The estimate for compound 4 lay 5.7 percentage points above the measured number; low and high end bracket the measured number.
By their numbers in this assay, from the lowest: compound 2; then compounds 4 and 1 (each within the scatter of the next); then compound 3.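

In this assay, 4-cyanophenyl in place of 2-chlorophenyl on the aromatic nitrogen gives a number 7.3 percentage points lower from compound 1 to compound 4 (within the scatter) in the first one-place step available in this set. The two compounds therefore cannot be told apart in this read-out, even though the entering group brings a nitrile with its triple bond and the leaving group takes its chlorine away. At this position, then, one substituted phenyl ring can stand in for another without a change that can be distinguished from ordinary repeat variation, although this rests on a single pair, and no measurement here gives a reason for the result or links it to a property of either group.

This step changes both the substituent and where it sits on the phenyl ring, so the compounds shown leave open what each change would do alone, which 4-chlorophenyl or 2-cyanophenyl on the same nitrogen could separate. They also leave open how far the tolerance extends, for example to an unsubstituted phenyl, a benzyl group, or a phenyl ring carrying an amine or a carboxylic acid.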